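A few compounds are considered here, and "the series" means these few. Any claim that something is new, unique, unknown or untested is made for them only; others in the source may bear on it.

The measured compounds:
- Compound 1 `c1ccc(Cn2nnc3c(NC4CCCC4)ncnc32)cc1` gives 127 nM in an assay on cell membranes for binding affinity to adenosine receptor A1 (Bos taurus), read by radioligand binding; a lower number here means a stronger inhibitor, a higher number a weaker inhibitor.
- Compound 2 `Cc1cccc(Nc2ncnc3c2nnn3Cc2ccccc2)c1` gives 1100 nM in this assay.
- Compound 3 `O=[N+]([O-])c1ccc(CNc2ncnc3c2nnn3Cc2ccccc2)cc1` gives only a limit in this assay, namely > 1000 nM.

On these data alone, compound 3 therefore stands at the limit of > 1000 nM in this assay, at which 1 of the 3 values shown sits; its exact value is unknown, only that it lies on the weak side of that boundary. Compound 4 `Nc1ccc(CNc2ncnc3c2nnn3Cc2ccccc2)cc1` differs from compound 3 in one place: amino in place of nitro on an aromatic carbon. The single measured step among these compounds, an 8.7-fold higher number from compound 1 to compound 2 (0.94 log units; beyond the scatter), alters a different part of the molecule, the group on a nitrogen on an aromatic ring, and does not touch the six-membered aromatic ring of carbon only where the nitro sits. Among the measured compounds shown here, no measured step bears on exchanging a nitro for an amino at that position, so the expectation rests on compound 3 alone. Compound 3 sits at the limit, and compound 4 is expected to remain weak in this assay as well, with a wide range around the guess. The estimated step is a step that the limit leaves unreadable from compound 3 to compound 4. Compound 4 is expected at 3000 nM, within a range from 500 nM to 20000 nM.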

Compound 4, inhibition constant: 9500 nM
Compound 4: middle estimate off by 3.2-fold (0.50 log units), on the low side; the range from low to high includes it.
By their numbers in this assay, from the lowest: compound 1; then compound 2; then compound 4.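

Compound 3 has only a limit, so the exchange of nitro for amino on this ring cannot be read in size or direction: the limit of > 1000 nM in this assay, at which 1 of the 4 values shown sits.

What compound 4 adds is an exact value for a benzyl group carrying a substituent on the ring, attached to this nitrogen. In this assay, 4-aminobenzyl gives an 8.6-fold higher number from compound 2 to compound 4 (0.94 log units; beyond the scatter), and it gives a 75-fold higher number from compound 1 to compound 4 (1.87 log units; beyond the scatter). Among the three compounds with exact values, the cyclopentyl group of compound 1 therefore keeps the lowest number, and 4-aminobenzyl has the highest.

On these data alone, whether amino improves or worsens on nitro remains open. Also open, as far as these compounds go, is how a benzyl group with a bare ring, or with a methoxy group or a carboxylic acid in place of the amino, would compare.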